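Swapping methyl for fluoro beside the ether in compound 1

The compounds below may be only part of what the source reports. "The series", "measured", "known", "first", "only" and "open" are said of these compounds alone.

Compound 1, `COC(=O)Nc1cc(-c2ccc(OC[C@@](C)(N)CC(C)C)c(C)c2)ccn1`, was tested in an assay on brain (strain C57BL6) for displacement of a labelled ligand from AP2-associated protein kinase 1 (Mus musculus), read by scintillation counting, with a stated time of 1 h (on this read-out lower numbers stand for stronger inhibition and higher numbers for weaker inhibition), and gave 0.08 nM, the lowest number among the three compounds measured. Among the measured compounds shown here, compound 2, `COC(=O)Nc1cc(-c2ccc(OC[C@@](C)(N)CC(C)C)c(C)c2C)ccn1`, gave 0.26 nM, and the step of a 3.3-fold higher number from compound 1 to compound 2 (0.51 log units; beyond the scatter) is the only single change measured here. Compound 3, `CC(=O)Nc1cc(-c2ccc(OC[C@@H](N)CC(C)C)cc2)ccn1`, gave 0.9 nM, but it differs from compound 1 in several places at once. Compound 4, `COC(=O)Nc1cc(-c2ccc(OC[C@@](C)(N)CC(C)C)c(F)c2)ccn1`, differs from compound 1 by fluoro in place of methyl on an aromatic carbon. For the measured compounds named here, no measured step covers this exchange, so the expectation rests on compound 1 alone and carries wide uncertainty. A step of about a 1.9-fold higher number from compound 1 to compound 4 (0.27 log units; within the scatter) is expected, most likely within the scatter or slightly toward a higher number. Compound 4 is therefore estimated at 0.15 nM, within a range of 0.05 nM to 0.5 nM.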

Compound 4, inhibition constant: 0.2 nM
Compound 4: the middle estimate sits 1.3-fold (0.12 log units) below what was measured; the measured number falls inside the stated range.
By their numbers in this assay, from the lowest: compound 1; then compounds 4 and 2 (each within the scatter of the next); then compound 3.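

In this assay, fluoro in place of methyl, ortho to the (2-amino-2,4-dimethylpentyl)oxy group, gives a 2.5-fold higher number from compound 1 to compound 4 (0.40 log units; beyond the scatter). This is the first change shown at this position, and it shows that even an exchange of one heavy atom for one heavy atom can move the number beyond the scatter. Nothing measured here gives a reason for this step.

Fluoro is the only replacement for this methyl among the compounds shown, so it remains open how chloro, ethyl or methoxy would read at the same position.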